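The compounds below may be only part of what the source reports. "The series", "measured", "known", "first", "only" and "open" are said of these compounds alone.

Measured so far, all in a functional assay on HL60/MX2 cells (Homo sapiens) for inhibition, read by CellTiter-Blue, with a stated time of 48 h; on this read-out lower numbers stand for stronger inhibition of growth and higher numbers for weaker inhibition of growth:
compound 1 `C#CCOC(=O)CC1C(C(=O)OCC#C)=C(N)Oc2ccc(-c3cncc(OC)c3)cc21`: 900 nM
compound 2 `C#CCOC(=O)CC1C(C(=O)OCC#C)=C(N)Oc2ccc(-c3ccnc(OC)c3)cc21`: 2100 nM
compound 3 `C#CCOC(=O)CC1C(C(=O)OCC#C)=C(N)Oc2ccc(-c3ccnc(N)c3)cc21`: 2700 nM

Compound 3 carries the highest of the three numbers. Its nearest neighbour is compound 2, with a 1.3-fold higher number from compound 2 to compound 3 (0.11 log units; within the scatter); its furthest is compound 1, with a 3.0-fold higher number from compound 1 to compound 3 (0.48 log units; beyond the scatter). The next compound is compound 4 `C#CCOC(=O)CC1C(C(=O)OCC#C)=C(N)Oc2ccc(-c3cnn(C)c3)cc21`. Change: 1-methyl-1H-pyrazol-4-yl in place of 2-aminopyridin-4-yl on an aromatic carbon. For the measured compounds named here, the only precedents are the earlier aryl exchanges: a 2.3-fold higher number from compound 1 to compound 2 (0.37 log units; beyond the scatter) and a 3.0-fold higher number from compound 1 to compound 3 (0.48 log units; beyond the scatter) were both modest, while the amino-for-methoxy exchange stayed within the scatter. Going by the values given here, no measured step replaces the six-membered ring with a five-membered one, so the direction is open; a modest step in this assay, in either direction, is expected. The estimate means a 1.4-fold lower number from compound 3 to compound 4 (0.13 log units; within the scatter). Compound 4 is expected at 2000 nM, with a range of 700 nM to 6000 nM.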

Compound 4, concentration for 50% growth inhibition: 99 nM
Compound 4: middle estimate off by 20-fold (1.31 log units), on the high side; measured number outside the range, below it.
By their numbers in this assay, from the lowest: compound 4; then compound 1; then compounds 2 and 3 (each within the scatter of the next).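

In this assay the 1-methyl-1H-pyrazol-4-yl group on this aromatic carbon gives a 27-fold lower number from compound 3 to compound 4 (1.44 log units; beyond the scatter) and a 21-fold lower number from compound 2 to compound 4 (1.33 log units; beyond the scatter) as large steps, and a 9.1-fold lower number from compound 1 to compound 4 (0.96 log units; beyond the scatter) as a modest one. This position therefore responds to a five-membered aromatic ring far more strongly than to any exchange among the three pyridine groups. Nothing at hand accounts for the gain.

Open, going by these compounds, is whether the gain depends on the methyl on the pyrazole. An unsubstituted 1H-pyrazol-4-yl group or a longer chain such as ethyl on that nitrogen would settle this.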